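Acetyl on the hydroxy group of compound 3

The compounds below may be only part of what the source reports. "The series", "measured", "known", "first", "only" and "open" are said of these compounds alone.

Compound 3 `O=c1c2cc([N+](=O)[O-])ccc2n(CCO)n1Cc1ccccc1` sits at the top of the range measured in an ADME assay on L929 cells (Mus musculus) for cytotoxicity, read by resazurin assay, with a stated time of 48 h; a higher number here means that more compound is tolerated, a lower number that less compound is tolerated. Its > 256000 nM is a limit of the assay. Compound 2 `CNC(=O)CCCn1c2ccc([N+](=O)[O-])cc2c(=O)n1Cc1ccccc1` gives > 256000 nM, also a limit. Compound 1 `O=c1c2cc([N+](=O)[O-])ccc2n(CCCBr)n1Cc1ccccc1` gives 25200 nM, and the record shows an at least 10-fold higher number from compound 1 to compound 3 (1.00 log units; beyond the scatter) and an at least 10-fold higher number from compound 1 to compound 2 (1.00 log units; beyond the scatter). Compound 4 `CC(=O)OCCn1c2ccc([N+](=O)[O-])cc2c(=O)n1Cc1ccccc1` carries acetyl in place of hydrogen on an oxygen on a saturated carbon. Among the measured compounds shown here, no measured step alters that oxygen, and both steps above replace the bromo end, so they guide only loosely. In this assay, a small downward step or none beyond the scatter is therefore expected. The expected change is an at least 1.1-fold lower number from compound 3 to compound 4 (0.06 log units; that floor lies within the scatter). For compound 4 the estimated value is 220000 nM, with an expected range of 70000 nM to 500000 nM.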

Compound 4, concentration lethal to 50% of the cells: > 256000 nM
Compound 4: no number, only a limit; the forecaster's own chance of this, stated with the estimate: 50%; at least 1.1-fold (0.06 log units) between middle value and limit.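

In this assay compound 4 gives > 256000 nM, which is a limit of the assay. The oxygen of the 2-hydroxyethyl chain therefore carries acetyl without a measurable value appearing, and the record shows an at least 10-fold higher number from compound 1 to compound 4 (1.00 log units; beyond the scatter). The steps to compound 4 from compound 2 and compound 3 cannot be read, because both ends of each are limits: the limit of > 256000 nM in this assay, at which 3 of the 4 values shown sit.

Going by these compounds, whether compound 3 and compound 4 truly differ stays open. So does whether an amine or a carboxylic acid at the end of this chain would also stay at the limit.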